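The source may report more compounds than this note shows. Statements on the series, on what has been measured and on what is new or still open speak of the compounds shown alone.

In an ADME assay on a cell-free system (plasma, Homo sapiens) for protein binding, compound 1 (`COCc1nc2nc(C)cc(Nc3ccc(C(F)(F)F)cc3)n2n1`) gives 75.6%, while compound 2 (`Cc1cc(Nc2ccc(S(F)(F)(F)(F)F)cc2)n2nc(C3CC3)nc2n1`) gives 97.7%, the lower unbound fraction of the two and a gap beyond the scatter. Compound 3 (`Cc1cc(Nc2ccc(C(F)(F)F)cc2)n2nc(C3CC3)nc2n1`) differs from compound 2 in one place: a group of 4 heavy atoms (1 carbon, 3 fluorine; no ring) in place of a group of 6 heavy atoms (5 fluorine, 1 sulfur; no ring), on an aromatic carbon, para to a large group. Within the data shown here, no measured pair isolates this change, so the expectation is loose: somewhat less binding and more free compound, at about the edge of the scatter. The estimated a 2.2-fold higher unbound fraction from compound 2 to compound 3 (0.34 log units; beyond the scatter) reflects that modest shift. Compound 3 is expected at 95%, with an estimated range of 89% to 97.5%.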

Compound 3, plasma protein binding: 92.8%
Beside the measured number, compound 3's estimate is 1.4-fold (0.16 log units) (unbound fraction) below it, within the range that was stated.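

In this assay, the step a 3.1-fold higher unbound fraction from compound 2 to compound 3 (0.50 log units; beyond the scatter) shows that trifluoromethyl in place of the larger fluorinated sulfur group on this aromatic carbon frees compound beyond the scatter, a change compounds 1 and 2 could not isolate. The other single change, cyclopropyl in place of methoxymethyl, gives a 3.4-fold lower unbound fraction from compound 1 to compound 3 (0.53 log units; beyond the scatter) and so moves binding the other way. Nothing here accounts for either step. As far as these compounds go, whether the first step holds with methoxymethyl on the core remains open. So does the effect of a nitrile on that aromatic carbon, or of an amine in place of cyclopropyl.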